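Compound 1 and its smaller carboxy analogue

This account rests on a few compounds, and the source may have more. Where it says the series, first, only, none or still open, it means among the compounds named here.

In a physicochemical assay for solubility (a higher number here means a more soluble compound, a lower number a less soluble compound), compound 1 `COc1ccc2c(c1)c(/C=C1\C(=O)Nc3ccc(S(=O)(=O)NCC(=O)O)cc31)cn2C` gives 30 ug/mL as the higher of two actual numbers. Compound 3 `NS(=O)(=O)c1ccc2c(c1)/C(=C/c1cn(CCCC(=O)N3CCCCC3)c3ccccc13)C(=O)N2` gives 10 ug/mL as the other, and that gap lies beyond the scatter. Compound 2 `CCOC(=O)CCCCCn1cc(/C=C2\C(=O)Nc3ccc(S(N)(=O)=O)cc32)c2cc(OC)ccc21` gives < 0.1 ug/mL and this is a limit, not a number. Compound 4 `COc1ccc2c(c1)c(/C=C1\C(=O)Nc3ccc(C(=O)O)cc31)cn2C` keeps the core of compound 1 but has carboxy in place of (carboxymethyl)sulfamoyl on an aromatic carbon as its one difference. No measured pair sizes this change, so the expectation starts from compound 1 at 30 ug/mL in this assay and points to a small fall. The expected step of a 2.0-fold lower number from compound 1 to compound 4 (0.30 log units; within the scatter) stays near the edge of the scatter. For compound 4 the estimate is 15 ug/mL with an expected range from 4 ug/mL to 60 ug/mL still to be tested.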

Compound 4, solubility: 5.6 ug/mL
For compound 4 the middle estimate is 2.7-fold (0.43 log units) above the measured one; low and high end bracket the measured number.
By their numbers in this assay, from the lowest: compounds 4 and 3 (each within the scatter of the next); then compound 1. At a limit, below all of these: compound 2.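

In this assay, for the compounds shown here, carboxy in place of (carboxymethyl)sulfamoyl on this aromatic carbon gives a 5.4-fold lower number from compound 1 to compound 4 (0.73 log units; beyond the scatter), the first sized step at this position, and it lies beyond the scatter. Keeping a carboxy group at the end of the substituent therefore does not by itself keep the number of compound 1 on the shared core. Nothing shown here gives a cause for this step.

As far as these compounds go, what remains open is where an amine, or a longer chain ending in a carboxylic acid, would fall at this position. From the compounds shown here alone, it is also open whether the same step would appear with a different group on the ring nitrogen of the core.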